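The source may report more compounds than this note shows. Statements on the series, on what has been measured and on what is new or still open speak of the compounds shown alone.

Measured compounds in an assay on isolated protein for inhibition of Leucine-rich repeat serine/threonine-protein kinase 2 variant G2019S (Homo sapiens), read by TR-FRET and LanthaScreen, with stated times of 50 min and 30 min, in the presence of a further agent that is not named here; a higher number here means a weaker inhibitor, a lower number a stronger inhibitor:
compound 1 `Cc1c(Nc2nc(N)c3c(C#N)c(N4CCC[C@H]4C)n(C)c3n2)cnn1C`: 43 nM
compound 2 `Cn1c(N2CCCC2)c(C#N)c2c(N)ncnc21`: 1910 nM
compound 3 `C[C@@H]1CCCN1c1c(C#N)c2c(N)ncnc2n1C`: 11 nM

Compound 3 gives the lowest number of the three. The nearest is compound 1, with a 3.9-fold lower number from compound 1 to compound 3 (0.59 log units; beyond the scatter) when the (1,5-dimethyl-1H-pyrazol-4-yl)amino group is replaced by hydrogen on an aromatic carbon. The furthest is compound 2, with a 170-fold lower number from compound 2 to compound 3 (2.24 log units; beyond the scatter) when a methyl enters on a saturated ring carbon. Both steps lie beyond the scatter.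

Compound 4 `C[C@@H]1CCCN1c1[nH]c2ncnc(N)c2c1C#N` has not been measured. It differs from compound 3 by hydrogen in place of methyl on an aromatic nitrogen. Neither measured step touches the aromatic nitrogen of the five-membered ring: one changes a substituent on an aromatic carbon, the other a substituent on the saturated ring. Within the data shown here, no step bearing directly on this change is available, and the two measured steps say only that both remote positions shift this assay strongly. Compound 4 keeps the 2-methylpyrrolidin-1-yl group that separates compound 3 from compound 2, so most of the potency is expected to remain, and the change at the ring nitrogen is expected to give a modest step in this assay, direction uncertain but leaning toward a higher number. Compound 4 is estimated at 30 nM, range 6 nM to 200 nM, an expected step of a 2.7-fold higher number from compound 3 to compound 4 (0.44 log units; beyond the scatter).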

Compound 4, half-maximal inhibitory concentration: 201 nM
For compound 4 the middle estimate is 6.7-fold (0.83 log units) below the measured one; the whole stated range lies below it.
By their numbers in this assay, from the lowest: compound 3; then compound 1; then compound 4; then compound 2.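

In this assay, among these compounds, the methyl on the aromatic nitrogen of the five-membered aromatic ring proves to be no minor detail: hydrogen in its place gives an 18-fold higher number from compound 3 to compound 4 (1.26 log units; beyond the scatter), the first direct reading at this position. In size, this change on the aromatic nitrogen stands above the replacement of the (1,5-dimethyl-1H-pyrazol-4-yl)amino group, a 3.9-fold lower number from compound 1 to compound 3 (0.59 log units; beyond the scatter), and below the entry of the methyl on the saturated ring, a 170-fold lower number from compound 2 to compound 3 (2.24 log units; beyond the scatter), so a single methyl at this position counts for much even with the 2-methylpyrrolidin-1-yl group kept in place. Nothing measured here accounts for the size of the step at the aromatic nitrogen.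

The compounds shown carry only methyl or hydrogen on this nitrogen, so the response to an ethyl group, a longer chain, or a chain ending in an amine or a carboxylic acid remains open. Also open, going by these compounds, is whether the same change would give a step of similar size on compound 1, with its (1,5-dimethyl-1H-pyrazol-4-yl)amino group, or on compound 2, which lacks the methyl on the saturated ring.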